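The source may hold more compounds than are shown below. What is called first, only, known or untested is meant among the compounds shown, and "the series" means these compounds.

Measured so far in a functional assay on KB cells (Homo sapiens) for inhibition; on this read-out lower numbers stand for stronger inhibition and higher numbers for weaker inhibition:

compound 1, `N=C(NN)c1cn([C@@H]2O[C@H](CO)[C@@H](O)[C@H]2O)c2nnnc(N)c12`: 3000 nM
compound 2, `CN(N)c1nnnc2c1c(C#N)cn2[C@@H]1O[C@H](COC(=O)c2ccccc2)[C@@H](OC(=O)c2ccccc2)[C@H]1OC(=O)c1ccccc1`: reads > 10000 nM, which is a limit of the assay rather than a number
compound 3, `NC(=O)c1cn([C@@H]2O[C@H](COC(=O)c3ccccc3)[C@@H](OC(=O)c3ccccc3)[C@H]2OC(=O)c2ccccc2)c2nnnc(O)c12`: reads > 10000 nM, again a limit and not a number

Among the compounds with values here, compound 1 is therefore the only member of the set with an actual number in this assay. Compound 2 and compound 3 both sit at the limit of > 10000 nM in this assay, at which 2 of the 3 values shown sit. Within the data shown here, since both of those are limits, nothing can be said about how far either lies from compound 1, and no step between measured compounds is available for the series.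

Compound 4, `COC(=N)c1cn([C@@H]2O[C@H](CO)[C@@H](O)[C@H]2O)c2nnnc(N)c12`, has not been measured. It differs from compound 1 in one place: methoxy in place of aminoamino on a carbon with a double bond to nitrogen. Among the measured compounds shown here, the data give no precedent for what this exchange does in this assay, so the expectation rests on compound 1 alone. The step from compound 1 to compound 4 is estimated at a 1.7-fold higher number from compound 1 to compound 4 (0.22 log units; within the scatter), that is, within the usual scatter of repeated measurements, with the uncertainty leaning toward weaker inhibition. Compound 4 is expected to give about 5000 nM in this assay, with a plausible range from 1500 nM to 20000 nM.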

Compound 4, half-maximal inhibitory concentration: 20000 nM
For compound 4 the middle estimate is 4.0-fold (0.60 log units) below the measured one, within the range that was stated.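

Methoxy in place of aminoamino on a carbon with a double bond to nitrogen gives, in this assay, a 6.7-fold higher number from compound 1 to compound 4 (0.82 log units; beyond the scatter), which is the first step readable in this series and lies beyond the scatter. It shows that this position is not indifferent to the group it carries, and that this exchange moves the read-out towards weaker inhibition. The exchange leaves the heavy-atom count and the hydrogen-bond acceptor count unchanged and removes the hydrogen-bond donors of aminoamino, since methoxy has none, but this single pair shows only that the two go together.

Whether the loss of those donors or some other difference between the two groups accounts for the step stays open, as no measured property here bears on it. A single exchange on the core of compound 1 also leaves open how other groups on this carbon would behave: a simple amine, with donors but without the second nitrogen of aminoamino, and ethoxy, a longer chain than methoxy without donors, would help to separate these possibilities.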